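The source may hold more compounds than are shown below. What is called first, only, known or untested is meant among the compounds shown, and "the series" means these compounds.

Measured in a functional assay on HCT-116 cells (Homo sapiens) for antiproliferative activity, read by MTT assay, with a stated time of 72 h; a lower number here means a stronger inhibitor, a higher number a weaker inhibitor:
- Compound 1 `O=C1O[C@H]([C@@H](O)Cn2cc(-c3cc(C(F)(F)F)cc(C(F)(F)F)c3)nn2)C(OCc2ccccc2)=C1OCc1ccccc1`: 57200 nM
- Compound 2 `Cc1ccc(-c2cn(C/C=C3\OC(=O)C(OCc4ccccc4)=C3OCc3ccccc3)nn2)cc1`: > 100000 nM, a limit of the assay
- Compound 3 `O=C1O[C@H]([C@@H](O)Cn2cc(CNS(=O)(=O)c3ccc(F)cc3)nn2)C(OCc2ccccc2)=C1OCc1ccccc1`: 22900 nM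

Compound 3, at 22900 nM, gives the lowest actual number, and compound 1, at 57200 nM, lies higher, beyond the scatter.

Compound 4 `C[Si](C)(C)c1cn(C[C@H](O)[C@H]2OC(=O)C(OCc3ccccc3)=C2OCc2ccccc2)nn1` carries a group of 4 heavy atoms (3 carbon, 1 silicon; no ring) on an aromatic carbon, in place of the (((4-fluorophenyl)sulfonyl)amino)methyl of compound 3: a group of 4 heavy atoms (3 carbon, 1 silicon; no ring) in place of a group of 12 heavy atoms (7 carbon, 1 nitrogen, 2 oxygen, 1 fluorine, 1 sulfur; one six-membered aromatic ring of carbon only), on an aromatic carbon. Among the measured compounds shown here, no measured pair isolates this change.

The estimated step is a 1.7-fold higher number from compound 3 to compound 4 (0.24 log units; within the scatter), leaning toward a higher number in this assay but expected to stay within the scatter. For compound 4 the expected value is 40000 nM, with an estimated range of 14000 nM to 100000 nM.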

Compound 4, half-maximal inhibitory concentration: 31800 nM
Estimate against measurement, compound 4: 1.3-fold (0.10 log units) above; the measured number falls inside the stated range.
By their numbers in this assay, from the lowest: compounds 3, 4 and 1 (each within the scatter of the next, the first and the last beyond it). At a limit, above all of these: compound 2.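

Exchanging the (((4-fluorophenyl)sulfonyl)amino)methyl on this aromatic carbon for a group of 3 carbon and 1 silicon with no ring gives, in this assay, a 1.4-fold higher number from compound 3 to compound 4 (0.14 log units; within the scatter). At this position, then, the two compounds do not separate, even though the entering group has no six-membered aromatic ring and no hydrogen-bond donor or acceptor. No measurement at hand bears on why this is so. On these data alone, whether an amine, a carboxylic acid or a longer chain on this carbon would stay level with compound 3 remains open.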